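Phenyl in Place of Hydroxypentyl on the Shared Core

The source may report more compounds than this note shows. Statements on the series, on what has been measured and on what is new or still open speak of the compounds shown alone.

Compound 3 `CCCCC(O)c1ccc(CN(CCCCCCC(=O)O)S(C)(=O)=O)cc1` was tested in an assay on HEK293 cells for inhibition of prostaglandin E2 receptor EP4 subtype (Rattus norvegicus); on this read-out higher numbers stand for weaker inhibition and lower numbers for stronger inhibition. Its result is a limit of the assay rather than a number: compound 3 gives > 3200 nM. Two other compounds were measured alongside it. Compound 1 `CC(C)(C)c1ccc(CN(Cc2cccc(CCC(=O)O)c2)S(=O)(=O)c2nccs2)cc1` also reaches only a limit, giving > 3200 nM in this assay. Compound 2 `CCCCc1ccc(CN(c2ccccc2CCCC(=O)O)S(C)(=O)=O)cc1` likewise stops at a limit, with > 3200 nM. So compound 3 stands exactly where every measured compound stands, namely at the limit of > 3200 nM in this assay, at which 3 of the 3 values shown sit; none of the three gives a real number, and no step between measured compounds can be sized from these results.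

Compound 4 `CS(=O)(=O)N(CCCCCCC(=O)O)Cc1ccc(-c2ccccc2)cc1` has not been measured. It differs from compound 3 in one place: phenyl in place of 1-hydroxypentyl on an aromatic carbon. Within the data shown here, no measured step exists that could show how large an effect such a change has in this assay. Among the measured compounds shown here, because the only evidence available is the limit of > 3200 nM in this assay, at which 3 of the 3 values shown sit, compound 4 is expected to remain near that limit as well, and the step that the limit leaves unreadable from compound 3 to compound 4 is estimated to be small, not beyond the usual scatter, with no clear direction. Compound 4 is therefore expected to give about 5000 nM, with a range from 1500 nM to 20000 nM.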

Compound 4, half-maximal inhibitory concentration: > 3200 nM
Compound 4: only a limit was reported; the forecaster's own chance of this, stated with the estimate: 60%; the middle value lies beyond the limit too.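

In this assay compound 4 gives > 3200 nM, which is a limit of the assay and not a number. Compound 3 also stops at a limit, so the size of the step between compound 3 and compound 4 cannot be read. The compounds shown leave open which structure, if any, would give a real number, as all of them share one result: the limit of > 3200 nM in this assay, at which 4 of the 4 values shown sit.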